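The source may report more compounds than this note shows. Statements on the series, on what has been measured and on what is new or still open speak of the compounds shown alone.

Compound 1 `CCCOC(=O)N1CCC(Oc2ncnc3c2CCN3c2ccc(S(C)(=O)=O)cc2F)CC1` gives 111% in a functional assay on CHO-K1 cells with Glucose-dependent insulinotropic receptor (Homo sapiens) as the target, read by a luciferase reporter, with a stated time of 5 h; on this read-out higher numbers stand for larger maximal responses and lower numbers for smaller maximal responses. Compound 2 `CC(C)COC(=O)N1CCC(Oc2ncnc3c2CCN3c2ccc(S(C)(=O)=O)cc2F)CC1` gives 94%. Compound 3 `Cc1nc(OC2CCN(C(=O)OC(C)(C)C)CC2)c2c(n1)N(c1ccc(S(C)(=O)=O)cc1F)CC2` gives 69%.

Compound 2 and compound 1 differ only in that (hydrogen in place of methyl on a saturated chain carbon bound to two saturated chain carbons), and this brought a number 17 percentage points higher from compound 2 to compound 1 (beyond the scatter). How the core of compound 3 differs from that of compound 2 is not broken down here; compound 3 simply sits at the lowest of the three values. Compound 4 `Cc1nc(OC2CCN(C(=O)OC(C)C)CC2)c2c(n1)N(c1ccc(S(C)(=O)=O)cc1F)CC2` has not yet been measured. It differs from compound 3 in that (hydrogen in place of methyl on a saturated chain carbon bound to an oxygen next to a carbonyl group and two saturated chain carbons), the same kind of change as from compound 2 to compound 1, but here at a saturated chain carbon bound to an oxygen next to a carbonyl group and two saturated chain carbons rather than one bound only to two saturated chain carbons. Because the earlier change gave a number 17 percentage points higher from compound 2 to compound 1 (beyond the scatter), a similar rise is expected, a number 13 percentage points higher from compound 3 to compound 4 (beyond the scatter). Compound 4 is estimated at 82%, between 65% and 100%.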

Compound 4, largest response reached (reported as percent of maximum), in percent of the reference or control that the assay uses: 45%
For compound 4 the middle estimate is 37 percentage points above the measured one, and the stated range ends above it.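

In this assay the change of methyl to hydrogen brought a number 24 percentage points lower from compound 3 to compound 4 (beyond the scatter), so in these compounds its result does not carry from one core to the other: the same change on two cores in this assay, a number 17 percentage points higher (beyond the scatter) from compound 2 to compound 1 and a number 24 percentage points lower (beyond the scatter) from compound 3 to compound 4, 41 percentage points apart, beyond the scatter of two such steps. This does not show why the result reverses, as the two pairs differ both in the core and in the carbon where the change falls, and two pairs cannot separate these. Nor does it give a rule for any other core, since each direction rests on a single pair.

The compounds shown leave open how a tert-butoxycarbonyl or isopropoxycarbonyl group would read on the core of compound 1. They also leave open how the core of compound 3 would respond to a longer chain or a cyclopropyl group in that place.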